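From hydroxymethyl to methylsulfonyl at the assay limit

The source may hold more compounds than are shown below. What is called first, only, known or untested is meant among the compounds shown, and "the series" means these compounds.

In an ADME assay on MRC5 cells (Homo sapiens) for cytotoxicity, read by fluorescence, with a stated time of 72 h (a higher number here means a weaker inhibitor, a lower number a stronger inhibitor), compound 1 (`CC1(COc2ccc(OC(F)(F)F)cc2)Cn2cc([N+](=O)[O-])nc2O1`) gives > 64000 nM as a limit of the assay. Compound 2 (`CC1(COc2ccc(OC(F)(F)F)cc2)Cn2cc(C=O)nc2O1`) gives > 64000 nM as a limit too. Compound 3 (`CC1(COc2ccc(OC(F)(F)F)cc2)Cn2cc(CO)nc2O1`) gives > 64000 nM as a limit as well. Compound 3 therefore has no number of its own, and the record shows only the limit of > 64000 nM in this assay, at which 3 of the 3 values shown sit, for this series.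

Compound 4 (`CC1(COc2ccc(OC(F)(F)F)cc2)Cn2cc(S(C)(=O)=O)nc2O1`) carries methylsulfonyl in place of hydroxymethyl on an aromatic carbon of the shared core. For the measured compounds named here, three measured steps bear on this place: a step that the two limits leave unreadable from compound 1 to compound 2 and a step that the two limits leave unreadable from compound 1 to compound 3 and a step that the two limits leave unreadable from compound 2 to compound 3 give no size to build on. All three groups tried there sit at the same limit (the limit of > 64000 nM in this assay, at which 3 of the 3 values shown sit), so compound 4 is expected to behave alike in this assay with no step beyond the scatter. The expected change is a number no higher from compound 3 to compound 4 (the limit leaves the size open) in this estimate. For compound 4 the estimate is 64000 nM with an expected range from 32000 nM to 128000 nM and a reading at the limit is the likeliest result.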

Compound 4, half-maximal inhibitory concentration: > 64000 nM
Compound 4: a limit, no number; the forecaster's own chance of this, stated with the estimate: 85%; the middle value sits exactly at the limit.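

In this assay compound 4 gives a limit, as do compounds 1, 2 and 3, so no step between any of them can be read: the limit of > 64000 nM in this assay, at which 4 of the 4 values shown sit.

The compounds shown leave open whether nitro, formyl, hydroxymethyl and methylsulfonyl differ at all, since none of the four compounds has a number of its own.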